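Chain-length series: swapping the furanoyl amide on compound 3

The compounds below may be only part of what the source reports. "The series", "measured", "known", "first", "only" and "open" are said of these compounds alone.

The shared core is varied at the amide chain. Compound 1 `CCCCCCCCNC(=O)[C@@H](NC(=O)c1ccco1)[C@@H](C)O` gives 91800 nM in a functional assay on MCF7 cells (Homo sapiens) for cytotoxicity, read by MTT assay, with a stated time of 48 h; a higher number here means a weaker inhibitor, a lower number a stronger inhibitor; compound 2 `CCCCCCCCCCCCCCNC(=O)[C@@H](NC(=O)c1ccco1)[C@@H](C)O` gives 105000 nM; compound 3 `CCCCCCCCCCCCCCCCCCNC(=O)[C@@H](NC(=O)c1ccco1)[C@@H](C)O` gives 21400 nM, the lowest of the three numbers, with a 4.3-fold lower number from compound 1 to compound 3 (0.63 log units; beyond the scatter) and a 4.9-fold lower number from compound 2 to compound 3 (0.69 log units; beyond the scatter), whereas a 1.1-fold higher number from compound 1 to compound 2 (0.06 log units; within the scatter). Compound 4 `CCCCCCCCCCCCCCCCCCNC(=O)[C@@H](NC(=O)/C=C/c1ccccc1)[C@@H](C)O` keeps the chain of compound 3 and alters the acyl group: 2-phenylethenyl in place of furan-2-yl on a carbonyl carbon. Going by the values given here, none of the measured steps touches this position; all three concern the chain alone, so they offer no direct measure of the acyl change. Lacking such a precedent, no step beyond the scatter is expected, a 1.0-fold lower number from compound 3 to compound 4 (0.01 log units; within the scatter). Compound 4 is therefore estimated at 21000 nM, with a range from 7000 nM to 63000 nM kept wide to reflect the missing precedent.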

Compound 4, half-maximal inhibitory concentration: 39200 nM
For compound 4 the middle estimate is 1.9-fold (0.27 log units) below the measured one; the measured number falls inside the stated range.
By their numbers in this assay, from the lowest: compounds 3 and 4 (each within the scatter of the next); then compounds 1 and 2 (each within the scatter of the next).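

Going by these compounds alone, replacing furan-2-yl with 2-phenylethenyl on a carbonyl carbon gives the first reading at this position in this assay, with a 1.8-fold higher number from compound 3 to compound 4 (0.26 log units; within the scatter) at the chain of compound 3. At this chain length, the position therefore accepts a carbon-only six-membered aromatic ring with an added double bond, and the step stays within the scatter. No accompanying measurement bears on this result.

Still open, as far as these compounds go, is whether the chain-length steps carry over to the 2-phenylethenyl amide. Also open, from the compounds shown here alone, is how a phenyl or a saturated 2-phenylethyl group would read on this carbonyl carbon.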